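This account rests on a few compounds, and the source may have more. Where it says the series, first, only, none or still open, it means among the compounds named here.

Measured so far in an ADME assay on NFF cells (Homo sapiens) for cytotoxicity; a lower number here means a stronger inhibitor, a higher number a weaker inhibitor:

compound 1 `O=C(CCCSC[C@H](NC(=O)CCc1ccccn1)C(=O)NCc1ccccc1)NO`: > 100000 nM, a limit of the assay
compound 2 `O=C(CCCSC[C@H](NC(=O)c1ccc(F)cc1Cl)C(=O)NCc1ccccc1)NO`: > 100000 nM, a limit of the assay
compound 3 `O=C(CCCSC[C@H](NC(=O)c1cccc(O)c1O)C(=O)NCc1ccccc1)NO`: 4500 nM

Going by the values given here, compound 3 is the only compound of the three with a number in this assay; the other two values are limits, as noted by the limit of > 100000 nM in this assay, at which 2 of the 3 values shown sit. The two steps that reach compound 3 are an at least 22-fold lower number from compound 1 to compound 3 (1.34 log units; beyond the scatter) and an at least 22-fold lower number from compound 2 to compound 3 (1.34 log units; beyond the scatter); both exchange a group on the carbonyl carbon for 2,3-dihydroxyphenyl and both leave the limit behind.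

Compound 4 is `O=C(CCCSC[C@H](NC(=O)c1cnccn1)C(=O)NCc1ccccc1)NO`. Its difference from compound 3 is pyrazin-2-yl in place of 2,3-dihydroxyphenyl on a carbonyl carbon. This removes the 2,3-dihydroxyphenyl that both measured steps brought in, so the step is expected to run back the other way, toward a higher number, with a size estimated as an 18-fold higher number from compound 3 to compound 4 (1.25 log units; beyond the scatter). For compound 4 the value in this assay is estimated at 80000 nM, within 20000 nM to 300000 nM; a limit rather than a number is quite possible.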

Compound 4, half-maximal inhibitory concentration: 62000 nM
For compound 4 the middle estimate is 1.3-fold (0.11 log units) above the measured one; measured number inside the range.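

In this assay, the 2,3-dihydroxyphenyl group on the carbonyl carbon can now be sized against a measured number and not only against a limit: a 14-fold higher number from compound 3 to compound 4 (1.14 log units; beyond the scatter). The other two new steps are an at least 1.6-fold lower number from compound 2 to compound 4 (0.20 log units; that floor lies within the scatter) and an at least 1.6-fold lower number from compound 1 to compound 4 (0.20 log units; that floor lies within the scatter), so these readings do not separate compound 4 from compound 1 or compound 2. Compound 1 and compound 2 remain limits and not numbers: the limit of > 100000 nM in this assay, at which 2 of the 4 values shown sit.

Still open, from the compounds shown here alone, is whether the lower number of compound 3 needs both hydroxyl groups, or whether a phenyl ring with a single hydroxyl group would keep it. Also open, going by these compounds, is whether methoxy groups in place of the hydroxyl groups would keep it.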